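Compound 4: A New Side Group on a Shared Core

The source may report more compounds than this note shows. Statements on the series, on what has been measured and on what is new or still open speak of the compounds shown alone.

Of the compounds shown here, three sharing one core have been measured in a functional assay on MCF7 cells (Homo sapiens) for cytotoxicity, read by sulforhodamine B assay, with a stated time of 72 h; on this read-out higher numbers stand for weaker inhibition and lower numbers for stronger inhibition. Compound 1 `O=C(Nc1ccc(Nc2ncnc3c2cnn3-c2ccccc2)cc1)Nc1ccccc1Cl` gives 55100 nM, compound 2 `O=C(Nc1ccc(Nc2ncnc3c2cnn3-c2ccccc2)cc1)Nc1cccc(Cl)c1` gives 4200 nM, and compound 3 `O=C(Nc1ccc(Nc2ncnc3c2cnn3-c2ccccc2)cc1)Nc1cccc(Br)c1` gives 36300 nM. The measured difference, a 1.5-fold lower number from compound 1 to compound 3 (0.18 log units; within the scatter), leaves those two level at the weak end, and compound 2 is the most potent of the three. Swapping only the halogen-bearing phenyl group can matter, as shown by a 13-fold lower number from compound 1 to compound 2 (1.12 log units; beyond the scatter) and by an 8.6-fold higher number from compound 2 to compound 3 (0.94 log units; beyond the scatter).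

Compound 4 `Clc1ccc(COc2ccc(Nc3ncnc4c3cnn4-c3ccccc3)cc2)cc1` carries a much larger change, with (4-chlorobenzyl)oxy in place of ((3-bromophenyl)carbamoyl)amino on an aromatic carbon. Within the data shown here, no measured step tests this replacement, so the data give no firm direction, and the large halogen steps argue for a wide range. The expected step is a 1.5-fold lower number from compound 3 to compound 4 (0.16 log units; within the scatter), so no change beyond the scatter is predicted with any confidence. The estimated value for compound 4 is 25000 nM. The estimated range for compound 4 runs from 5000 nM to 100000 nM.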

Compound 4, half-maximal inhibitory concentration: 4360 nM
Compound 4: middle estimate off by 5.7-fold (0.76 log units), on the high side; measured number outside the range, below it.
By their numbers in this assay, from the lowest: compounds 2 and 4 (each within the scatter of the next); then compounds 3 and 1 (each within the scatter of the next).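

In this assay, this position accepts a very different side group: (4-chlorobenzyl)oxy in place of ((3-bromophenyl)carbamoyl)amino gives an 8.3-fold lower number from compound 3 to compound 4 (0.92 log units; beyond the scatter), and in place of ((2-chlorophenyl)carbamoyl)amino it gives a 13-fold lower number from compound 1 to compound 4 (1.10 log units; beyond the scatter). Against the ((3-chlorophenyl)carbamoyl)amino group, the same change gives a 1.0-fold higher number from compound 2 to compound 4 (0.02 log units; within the scatter), so those two stand level. The entering group carries no hydrogen-bond donors, so donors on this side group are not needed to reach the lowest numbers seen so far.

Nothing measured for these compounds bears on the reason for these results. The compounds shown leave open whether the chlorine on the benzyl ring matters, and how a plain benzyloxy group or a benzylamino group would compare at this position.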